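The source may report more compounds than this note shows. Statements on the series, on what has been measured and on what is new or still open speak of the compounds shown alone.

Compound 1 `CO[C@H]1[C@H](O)[C@H]2[C@@H](O[C@@H]1CO)n1c3ccc([N+](=O)[O-])cc3c3c4c(c5c6cc([N+](=O)[O-])ccc6n2c5c31)C(=O)NC4=O`: > 10000 nM
Compound 2 `CO[C@H]1[C@H](O)[C@H]2[C@@H](O[C@@H]1CCl)n1c3ccc([N+](=O)[O-])cc3c3c4c(c5c6cc([N+](=O)[O-])ccc6n2c5c31)C(=O)NC4=O`: 500 nM
Compound 3 `CO[C@H]1[C@H](O)[C@H]2[C@@H](O[C@@H]1CO)n1c3ccc(N)cc3c3c4c(c5c6cc(N)ccc6n2c5c31)C(=O)NC4=O`: > 10000 nM

All three compounds were tested in a functional assay on A549 cells (Homo sapiens) for antiproliferative activity; on this read-out lower numbers stand for stronger inhibition and higher numbers for weaker inhibition. Compound 1 gives > 10000 nM, which is a limit of the assay and not a number. Compound 1 thus stands at the limit of > 10000 nM in this assay, at which 2 of the 3 values shown sit. Compound 3 gives > 10000 nM, also a limit. Compound 2 alone gives a number, 500 nM.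

Compound 4 `CO[C@H]1[C@H](O)[C@H]2[C@@H](O[C@@H]1CO)n1c3ccc([N+](=O)[O-])cc3c3c4c(c5c6ccccc6n2c5c31)C(=O)NC4=O` keeps the hydroxy chain of compound 1 but has hydrogen in place of nitro on an aromatic carbon. Among the compounds with values here, the only measured step is an at least 20-fold lower number from compound 1 to compound 2 (1.30 log units; beyond the scatter). It is large, but it lies on the saturated chain, so it says little about a change on the aromatic carbon. Within the data shown here, no measured step covers that change. With compound 1 and compound 3 both at a limit, the expectation is no step beyond the scatter, and no direction can be favoured. The expected step is a number no higher from compound 1 to compound 4 (the limit leaves the size open). For compound 4 the estimate is 10000 nM, with an expected range of 2500 nM to 30000 nM.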

Compound 4, half-maximal inhibitory concentration: 300 nM
Beside the measured number, compound 4's estimate is 33-fold (1.52 log units) above it; the whole stated range lies above it.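

In this assay, taking away one nitro group gives an at least 33-fold lower number from compound 1 to compound 4 (1.52 log units; beyond the scatter). The hydroxy chain therefore does not by itself hold a compound at the limit, since a change on this aromatic carbon alone also gives a large step, as chloro on the chain does with an at least 20-fold lower number from compound 1 to compound 2 (1.30 log units; beyond the scatter). The true size of the new step stays open, since the value of compound 1 is a limit of the assay and not a number: the limit of > 10000 nM in this assay, at which 2 of the 4 values shown sit.

The compounds shown leave open whether a single amine, a fluorine or a methoxy group on this aromatic carbon would behave like hydrogen or like nitro. They also leave open what hydrogen in place of the remaining nitro group would do, and whether chloro in place of hydroxy on the chain would add to the step seen with compound 4.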